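The source may report more compounds than this note shows. Statements on the series, on what has been measured and on what is new or still open speak of the compounds shown alone.

Of the compounds shown here, three sharing one core have been measured in an assay on cells for inhibition of Voltage-gated L-type calcium channel (Rattus norvegicus), read by fluorescence and calcium flux, with stated times of 30 min and 2 min; a lower number here means a stronger inhibitor, a higher number a weaker inhibitor. Compound 1 `COC(=O)C1=C(C)NC(C)=C(C(=O)OC)C1c1ccc(OCC(=O)N2CCCC(C)C2)c(OC)c1` gives 10000 nM, and compound 2 `COC(=O)C1=C(C)NC(C)=C(C(=O)OC)C1c1cccc(OCC(=O)N2CCN(C)CC2)c1` gives 10000 nM. Compound 3 `COC(=O)C1=C(C)NC(C)=C(C(=O)OC)C1c1cccc(OCC(=O)N2CCCC2)c1` gives 3600 nM, the lowest of the three numbers, separated from compound 1 and compound 2 by the same margin, which lies beyond the scatter. Going by the values given here, the one measured step that changes a single place, a 2.8-fold lower number from compound 2 to compound 3 (0.44 log units; beyond the scatter), swaps the amine of the amide on the carbonyl carbon.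

Compound 4 `COC(=O)COc1cccc(C2C(C(=O)OC)=C(C)NC(C)=C2C(=O)OC)c1` differs from compound 3 in the same region: methoxy in place of pyrrolidin-1-yl on a carbonyl carbon. Among the compounds with values here, no measured step swaps an amine for an oxygen at this carbonyl, so the only guidance is that the amine change from compound 2 to compound 3 moved the number modestly. A change of similar or smaller size is therefore expected, with no clear direction, and a 1.3-fold higher number from compound 3 to compound 4 (0.10 log units; within the scatter) is the estimated step. Compound 4 is expected to give about 4500 nM in this assay, within a range from 1500 nM to 10000 nM.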

Compound 4, half-maximal inhibitory concentration: 10000 nM
Beside the measured number, compound 4's estimate is 2.2-fold (0.35 log units) below it, and the stated range covers the measured number.
By their numbers in this assay, from the lowest: compound 3; then compounds 1, 2 and 4 (each within the scatter of the next).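

At the carbonyl carbon whose other neighbour is a saturated chain carbon, this assay now gives a direct amine-to-methoxy comparison: a 2.8-fold higher number from compound 3 to compound 4 (0.44 log units; beyond the scatter), so the lower number of compound 3 is not kept when methoxy replaces pyrrolidin-1-yl. With methoxy in place of 4-methylpiperazin-1-yl, there is no change at the digits printed from compound 2 to compound 4 (within the scatter), so among these three compounds only the one carrying pyrrolidin-1-yl stands apart. No evidence is available to explain this difference at the carbonyl carbon.

The compounds shown leave open whether another amine at this carbonyl, such as azetidin-1-yl or piperidin-1-yl, or a free carboxylic acid there would read like compound 3 or like compound 4. They also leave open whether pyrrolidin-1-yl would give a similar number on the differently substituted core of compound 1.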